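The source may hold more compounds than are shown below. What is called first, only, known or untested is meant among the compounds shown, and "the series" means these compounds.

Working notes on the series. Three measured compounds share one core and differ only in the group on the sulfonyl sulfur. Compound 1 `O=C(c1ccc(Cl)c(C(F)(F)F)c1)N1CCC(n2cncc2-c2ccc(OS(=O)(=O)c3cccc4ccccc34)cc2)CC1` gives 3520 nM in an assay on HEK293 cells for antagonist activity at P2X purinoceptor 7 (Homo sapiens), read by fluorescence, with a stated time of 2 h; on this read-out lower numbers stand for stronger inhibition and higher numbers for weaker inhibition. Compound 2 `O=C(NC1CC1)c1cccc(S(=O)(=O)Oc2ccc(-c3cncn3C3CCN(C(=O)c4ccc(Cl)c(C(F)(F)F)c4)CC3)cc2)c1` gives 88 nM in this assay, and the step of a 40-fold lower number from compound 1 to compound 2 (1.60 log units; beyond the scatter). Compound 3 `O=C(c1ccc(Cl)c(C(F)(F)F)c1)N1CCC(n2cncc2-c2ccc(OS(=O)(=O)c3cccc4cnccc34)cc2)CC1` gives 45 nM in this assay, the lowest number of the three; the step of a 78-fold lower number from compound 1 to compound 3 (1.89 log units; beyond the scatter), while the step of a 2.0-fold lower number from compound 2 to compound 3 (0.29 log units; within the scatter), so compounds 2 and 3 cannot be set apart on these numbers. Compound 4 `COc1ccc(C(=O)N2CCC(n3cncc3-c3ccc(OS(=O)(=O)c4cccc5cnccc45)cc3)CC2)cc1OC` is not yet measured. It departs from compound 3 elsewhere: 3,4-dimethoxyphenyl in place of 4-chloro-3-(trifluoromethyl)phenyl on a carbonyl carbon. Within the data shown here, no measured step bears on this change; all three concern the sulfonyl sulfur, and the group on the carbonyl carbon is held constant from compound 1 to compound 3, so nothing separates its contribution. The step from compound 3 to compound 4 is therefore estimated only loosely, as a 6.7-fold higher number from compound 3 to compound 4 (0.82 log units; beyond the scatter), with a wide range. Compound 4 is expected to give 300 nM, between 60 nM and 1500 nM.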

Compound 4, half-maximal inhibitory concentration: 259 nM
For compound 4 the middle estimate is 1.2-fold (0.06 log units) above the measured one; the range from low to high includes it.
By their numbers in this assay, from the lowest: compounds 3 and 2 (each within the scatter of the next); then compound 4; then compound 1.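

The group on the carbonyl carbon matters as well: 3,4-dimethoxyphenyl in place of 4-chloro-3-(trifluoromethyl)phenyl gives a 5.8-fold higher number from compound 3 to compound 4 (0.76 log units; beyond the scatter) in this assay with isoquinolin-5-yl held on the sulfonyl sulfur. Among these compounds, this modest step is the first reading at this position, and it is smaller than the change on the sulfonyl sulfur that gave a 78-fold lower number from compound 1 to compound 3 (1.89 log units; beyond the scatter) in the same assay. No measurement on hand gives a reason for the step.

The swap replaces chlorine and trifluoromethyl and brings in two methoxy groups at once, so the contribution of each stays unresolved. Also open, as far as these compounds go, are how an unsubstituted phenyl, a pyridine or a phenyl bearing an amine would read here, and whether the step holds with the 3-(cyclopropylcarbamoyl)phenyl group on the sulfonyl sulfur.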